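Phenyl on the anilide ring of compound 1

The source may hold more compounds than are shown below. What is called first, only, known or untested is meant among the compounds shown, and "the series" means these compounds.

Among the compounds with values here, in an ADME assay on WI-38 cells (Homo sapiens) for cytotoxicity, read by MTT assay, with a stated time of 72 h (on this read-out higher numbers stand for weaker inhibition and lower numbers for stronger inhibition), compound 1 `O=C(CCc1cccc2c1B(O)OC2)Nc1ccccc1` gives 30000 nM, the only true number so far. Compound 2 `CC(C)(C)OC(=O)Nc1ccc(NC(=O)CCc2cccc3c2B(O)OC3)cc1` reads > 100000 nM, which is a limit of the assay and not a number. Compound 3 `O=C(CCc1cccc2c1B(O)OC2)Nc1ccccc1-c1ccccc1` carries phenyl in place of hydrogen on an aromatic carbon, ortho to a large group. Within the data shown here, the sole measured step, an at least 3.3-fold higher number from compound 1 to compound 2 (0.52 log units; beyond the scatter), rests on the limit of > 100000 nM in this assay, at which 1 of the 2 values shown sits, and involves a different group, so it guides only weakly. On these data alone, no step beyond the scatter is therefore expected in this assay, though either direction remains open. The expected step is a 1.2-fold lower number from compound 1 to compound 3 (0.08 log units; within the scatter). For compound 3 the estimated value is 25000 nM, with an expected range of 8000 nM to 80000 nM.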

Compound 3, half-maximal inhibitory concentration: 77000 nM
Beside the measured number, compound 3's estimate is 3.1-fold (0.49 log units) below it; low and high end bracket the measured number.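

Phenyl in place of hydrogen, ortho to a large group, gives a 2.6-fold higher number from compound 1 to compound 3 (0.41 log units; beyond the scatter) in this assay. Within the data shown here, this is the first step that rests on two true numbers. Both changes on this ring now move the number upward, though with different groups, and the value for compound 2 remains a limit: the limit of > 100000 nM in this assay, at which 1 of the 3 values shown sits.

On these data alone, whether a methyl or an amine on the same carbon also gives a higher number stays open. So does whether a carboxylic acid on the added phenyl would shift the number.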